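Chloro to iodo in a small halogen series

The source may report more compounds than this note shows. Statements on the series, on what has been measured and on what is new or still open speak of the compounds shown alone.

Compound 1 `CCN1CCN(c2ccc(S(=O)(=O)Oc3cccc(F)c3)cc2)C1=O`: > 100000 nM (a limit)
Compound 2 `CCN1CCN(c2ccc(S(=O)(=O)Oc3cccc(Cl)c3)cc2)C1=O`: 5400 nM

Going by the values given here, in a functional assay on MCF7 cells (Homo sapiens) for antiproliferative activity, read by sulforhodamine B assay, with a stated time of 48 h (on this read-out higher numbers stand for weaker inhibition and lower numbers for stronger inhibition), compound 2 gives 5400 nM, the only exact number so far. Compound 1 sits at > 100000 nM, which is a limit of the assay. Compound 3 `CCN1CCN(c2ccc(S(=O)(=O)Oc3cccc(I)c3)cc2)C1=O` has iodo in place of chloro on an aromatic carbon. Among the compounds with values here, only one measured step bears on this, a large one, an at least 18-fold lower number from compound 1 to compound 2 (1.26 log units; beyond the scatter). It also swaps one halogen for another, so a smaller move in the same direction is expected in this assay. The expected change is a 2.2-fold lower number from compound 2 to compound 3 (0.33 log units; beyond the scatter). Compound 3 is estimated at 2500 nM, with an expected range of 600 nM to 12000 nM.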

Compound 3, half-maximal inhibitory concentration: 1900 nM
Compound 3: the middle estimate sits 1.3-fold (0.12 log units) above what was measured; the range from low to high includes it.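

Going by these compounds alone, for the first time, two exact numbers can be compared at this position, and in this assay the change to 3-iodophenyl gives a 2.8-fold lower number from compound 2 to compound 3 (0.45 log units; beyond the scatter) as a modest step in the same direction as the earlier one. Fluoro, chloro and iodo now fall in one order, with iodo giving the lowest number. The full span across the series is an at least 52-fold lower number from compound 1 to compound 3 (1.72 log units; beyond the scatter) and rests on a limit, not a number: the limit of > 100000 nM in this assay, at which 1 of the 3 values shown sits.

Where a bromo group would fall remains open. So does whether this position needs a halogen at all, which a methyl or methoxy group could test.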